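Compound 3 and a six-membered non-aromatic ring

The source may report more compounds than this note shows. Statements on the series, on what has been measured and on what is new or still open speak of the compounds shown alone.

In a physicochemical assay for solubility, in phosphate buffer, at pH 7.4 (a higher number here means a more soluble compound, a lower number a less soluble compound), compound 2 `CC(=O)N[C@@H]1CCC[C@H](C(=O)Nc2cc(-c3cnn4ccccc34)c(Cl)cn2)C1` stands lowest of two numbers at 45000 nM while compound 1 `CC(=O)N[C@@H]1CCC[C@H](C(=O)Nc2cc(-c3cnn4c3CCCC4)c(Cl)cn2)C1` gives 310000 nM as the other. Compound 3 `CC(=O)N[C@@H]1CCC[C@H](C(=O)Nc2cc(-c3cnc4n3CCCC4)c(Cl)cn2)C1` differs from compound 2 by a group of 9 heavy atoms (7 carbon, 2 nitrogen; one five-membered aromatic ring with 2 hetero atoms, one six-membered non-aromatic ring with 1 hetero atom) in place of a group of 9 heavy atoms (7 carbon, 2 nitrogen; one five-membered aromatic ring with 2 hetero atoms, one six-membered aromatic ring with 1 hetero atom), on an aromatic carbon on an aromatic carbon. Among the compounds with values here, the one measured step bearing on this is a 6.9-fold lower number from compound 1 to compound 2 (0.84 log units; beyond the scatter) and it ran the opposite way, from a six-membered non-aromatic ring to a six-membered aromatic ring. Within the data shown here, a rise of similar size is therefore expected, although the entering group is not the one carried by compound 1. The expected step in this assay is a 5.6-fold higher number from compound 2 to compound 3 (0.74 log units; beyond the scatter) on this reading. Compound 3 is estimated at 250000 nM with an expected range of 90000 nM to 600000 nM in this estimate.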

Compound 3, solubility: 600000 nM
For compound 3 the middle estimate is 2.4-fold (0.38 log units) below the measured one; low and high end bracket the measured number.
By their numbers in this assay, from the lowest: compound 2; then compounds 1 and 3 (each within the scatter of the next).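

In this assay compound 3 gives a second case in which the group with the six-membered non-aromatic ring carries the higher number, here as a 13-fold higher number from compound 2 to compound 3 (1.12 log units; beyond the scatter). Exchanging one such group for the other on this aromatic carbon gives a 1.9-fold higher number from compound 1 to compound 3 (0.29 log units; within the scatter), so these two groups are not told apart in this assay. Nothing measured here explains the difference between the aromatic and non-aromatic rings. As far as these compounds go, whether an amine or a hydroxyl group on the non-aromatic ring would preserve these numbers remains open.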